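The source may hold more compounds than are shown below. What is called first, only, known or untested is meant among the compounds shown, and "the series" means these compounds.

Compound 1 `CC(C)(O/N=C(\C(=O)N[C@@H]1C(=O)N(S(=O)(=O)O)[C@@H]1CN1CCNC1=O)c1csc(N)n1)C(=O)O`: > 1000 h
Compound 2 `CC(C)(O/N=C(\C(=O)N[C@@H]1C(=O)N(S(=O)(=O)O)[C@@H]1Cn1cnnc1)c1csc(N)n1)C(=O)O`: 113 h

These values come from a physicochemical assay for metabolic stability, read by HPLC and mass spectrometry, in phosphate buffer, at 37 degrees C, at pH 7.4; on this read-out lower numbers stand for a shorter-lived compound and higher numbers for a longer-lived compound. The entry for compound 1, > 1000 h, is a limit and not a number. Within the data shown here, compound 2, at 113 h, holds the only actual number so far. Compound 3 `C[C@@H]1CN(C[C@@H]2[C@H](NC(=O)/C(=N\OC(C)(C)C(=O)O)c3csc(N)n3)C(=O)N2S(=O)(=O)O)C(=O)O1` differs from it at one place: 5-methyl-2-oxo-1,3-oxazolidin-3-yl in place of 4H-1,2,4-triazol-4-yl on a saturated chain carbon bound to a saturated ring carbon. Among the measured compounds shown here, the one measured step bearing on this, an at least 8.8-fold lower number from compound 1 to compound 2 (0.94 log units; beyond the scatter), lies beyond the scatter and brought in the same 4H-1,2,4-triazol-4-yl. Compound 3 again carries a five-membered non-aromatic ring, so a rise of like size, the reverse of an at least 8.8-fold lower number from compound 1 to compound 2 (0.94 log units; beyond the scatter), is expected: an estimated 4.4-fold higher number from compound 2 to compound 3 (0.65 log units; beyond the scatter). For compound 3 the estimated half-life is 500 h, with an expected range of 150 h to 1500 h.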

Compound 3, half-life: > 37 h
Compound 3: only a limit was reported; the forecaster's own chance of this, stated with the estimate: 30%; the middle value lies beyond the limit too.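

Among these compounds, compound 3 gives > 37 h, which is a limit and not a number, so no step from compound 2 or compound 1 to compound 3 can be read. The compounds shown leave open how the half-life of compound 3 compares with those of compound 2 and compound 1.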